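Adding a Nonyl Chain to a Cytotoxic Nucleotide Prodrug

This account rests on a few compounds, and the source may have more. Where it says the series, first, only, none or still open, it means among the compounds named here.

Measured compounds:
compound 1 `CCCCCCCCCC[n+]1cccc(O)c1`: 126000 nM
compound 2 `CCOC(=O)C[n+]1cccc(O)c1`: > 200000 nM
compound 3 `O=C(O[C@H]1C[C@H](n2cc(F)c(=O)[nH]c2=O)O[C@@H]1COP(=O)(O)Oc1ccccc1)c1ccccc1`: 1270 nM

In a functional assay on MRC5 cells (Homo sapiens) for cytotoxicity, read by MTT assay, with a stated time of 48 h (a higher number here means a weaker inhibitor, a lower number a stronger inhibitor), which reads how strongly a compound harms a line of healthy human lung fibroblasts, compound 3 gives 1270 nM, the lowest of the two numbers shown. Compound 1 gives 126000 nM, a much higher number, a gap far beyond the usual scatter. For compound 2 the assay reports only (the limit of > 200000 nM in this assay, at which 1 of the 3 values shown sits), so no number is known for it.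

Compound 4 `CCCCCCCCCc1ccc(OP(=O)(O)OC[C@H]2O[C@@H](n3cc(F)c(=O)[nH]c3=O)C[C@@H]2OC(=O)c2ccccc2)cc1` differs from compound 3 in a single place: nonyl in place of hydrogen on an aromatic carbon. For the measured compounds named here, no measured pair shows this same change, so its effect can only be guessed. The expectation is a modest step, most likely toward a lower number, though one that may still fall within the scatter. Compound 4 is therefore estimated at 700 nM in this assay, with a likely range from 200 nM to 2500 nM. That estimate corresponds to an expected step of a 1.8-fold lower number from compound 3 to compound 4 (0.26 log units; within the scatter).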

Compound 4, half-maximal inhibitory concentration: 39900 nM
Beside the measured number, compound 4's estimate is 57-fold (1.76 log units) below it; the whole stated range lies below it.
By their numbers in this assay, from the lowest: compound 3; then compound 4; then compound 1. At a limit, above all of these: compound 2.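

The aromatic carbon para to a large group turns out to be a sensitive place: in this assay, nonyl in place of hydrogen gives a 31-fold higher number from compound 3 to compound 4 (1.50 log units; beyond the scatter), a large step toward weaker harm to these cells. So this chain, which has no ring and no net charge, changes the reading substantially even though the rest of the molecule stays the same. Nothing shown here accounts for the size of this step.

The compounds shown leave open whether a shorter chain such as methyl or butyl on the same carbon would give a smaller step, or whether even a small group is enough. They also leave open how an amine or a carboxylic acid at this place would read, so this single pair sets no trend.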